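The source may report more compounds than this note shows. Statements on the series, on what has been measured and on what is new or still open speak of the compounds shown alone.

In an ADME assay on Caco-2 cells (Homo sapiens) for permeability, in the apical to basolateral direction (a higher number here means that the compound crosses the layer faster, a lower number that the compound crosses the layer more slowly), compound 1 `Cn1nc2c(=O)n(CC3(O)CCN(Cc4ccc(-c5ccco5)cc4Cl)CC3)cnc2c1-c1ccc(C2(N)CC2)cc1` gives 1.99 10^-6 cm/s and compound 2 `Cn1nc2c(=O)n(CC3(O)CCN(Cc4ccc(-c5ccco5)cc4Cl)CC3)cnc2c1-c1ccc(CNC=O)cc1` gives 0.65 10^-6 cm/s while compound 3 `Cn1nc2c(=O)n(CC3(O)CCN(Cc4ccc(C5=CCCC5)cc4Cl)CC3)cnc2c1-c1ccc(CN)cc1` gives 0.23 10^-6 cm/s as the lowest of the three numbers. The next compound, compound 4 `Cn1nc2c(=O)n(CC3(O)CCN(Cc4ccc(-c5ccc(C(=O)O)o5)cc4Cl)CC3)cnc2c1-c1ccc(CN)cc1` differs from compound 3 at one place, with 5-carboxyfuran-2-yl in place of cyclopent-1-en-1-yl on an aromatic carbon as the full count of that change. Among the compounds with values here, no measured step touches this group. Within the data shown here, the only measured step is a 3.1-fold lower number from compound 1 to compound 2 (0.49 log units; beyond the scatter) and it comes from a different place, where (formylamino)methyl replaces 1-aminocyclopropyl, so it serves only as a rough guide to size. A modest drop of similar size is therefore expected in this assay as a judgement from the structural change alone, with no direct test in the data so far. The expected move is a 2.3-fold lower number from compound 3 to compound 4 (0.36 log units; beyond the scatter) on this reasoning. For compound 4 the estimated value is 0.1 10^-6 cm/s with an expected range from 0.03 10^-6 cm/s to 0.4 10^-6 cm/s on this reading.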

Compound 4, apparent permeability: 0.33 10^-6 cm/s
Estimate against measurement, compound 4: 3.3-fold (0.52 log units) below; the measured number falls inside the stated range.
By their numbers in this assay, from the lowest: compounds 3, 4 and 2 (each within the scatter of the next, the first and the last beyond it); then compound 1.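

This is the first change shown at the aromatic carbon that lies meta to a chloro group and para to a large group. In this assay, putting 5-carboxyfuran-2-yl in place of cyclopent-1-en-1-yl gives a 1.4-fold higher number from compound 3 to compound 4 (0.16 log units; within the scatter). A carbon-only ring and a larger aromatic ring bearing a hydrogen-bond donor and hydrogen-bond acceptors can therefore stand at this position with no difference that can be told from the scatter, and no measurement shown bears on why the two read alike.

Going by these compounds, the furan ring and its carboxylic acid enter together, so the share of each stays open. On these data alone, how a methyl ester or a primary amide in place of the carboxylic acid would read at this position also remains unknown.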